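A few compounds are considered here, and "the series" means these few. Any claim that something is new, unique, unknown or untested is made for them only; others in the source may bear on it.

Measured compounds:
Compound 1 `Fc1ccccc1Cn1nnc2c(NC3CCCCC3)nc(-c3ccccc3)nc21`: 1150000 nM
Compound 2 `CNc1nc(-c2ccccc2)nc2c1nnn2Cc1ccccc1F`: 25000000 nM

In an assay on isolated protein for binding affinity to adenosine receptor A1 (Bos taurus) (a higher number here means a weaker inhibitor, a lower number a stronger inhibitor), compound 2 gives 25000000 nM, the highest of the two numbers recorded. Among the compounds with values here, its nearest neighbour is compound 1, and the one measured step, a 22-fold higher number from compound 1 to compound 2 (1.34 log units; beyond the scatter), separates them; that step changes methyl in place of cyclohexyl on a nitrogen on an aromatic ring and is large.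

Compound 3 `CNc1nc(-c2ccccc2)nc2c1nnn2Cc1ccccc1` differs from compound 2 at a different site: hydrogen in place of fluoro on an aromatic carbon. Within the data shown here, no measured step touches this benzyl group, so the single step from compound 1 to compound 2 gives no direct guidance on a fluoro-to-hydrogen exchange there. With nothing to point either way, a step within the scatter is the expectation, no change at the digits printed from compound 2 to compound 3 (within the scatter). Compound 3 is therefore estimated at 25000000 nM in this assay, within a range of 8000000 nM to 80000000 nM.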

Compound 3, inhibition constant: 353000000 nM
For compound 3 the middle estimate is 14-fold (1.15 log units) below the measured one; measured number above the stated range.
By their numbers in this assay, from the lowest: compound 1; then compound 2; then compound 3.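

In this assay, the exchange of 2-fluorobenzyl to benzyl gives a 14-fold higher number from compound 2 to compound 3 (1.15 log units; beyond the scatter), a large step that the earlier pair could not reveal, since compound 1 and compound 2 share the 2-fluorobenzyl group. The benzyl group is therefore a second site that moves the number, not only the group on the nitrogen, and here the loss of one fluoro, with hydrogen in its place, gives the weaker inhibitor. Nothing available explains why this single-atom change has so large an effect.

The compounds shown leave open whether the same exchange would have a similar effect with cyclohexyl on the nitrogen, as in compound 1. They also leave open how chloro or methoxy would compare with fluoro and hydrogen on this aromatic carbon.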